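A few compounds are considered here, and "the series" means these few. Any claim that something is new, unique, unknown or untested is made for them only; others in the source may bear on it.

In a physicochemical assay for lipophilicity, measured as octanol-water partition, at pH 7.4 (a higher number here means a more lipophilic compound, a lower number a more polar compound), compound 2 (`Cc1ccc(Cn2c(=O)[nH]c3c(N)nc(C(F)(F)F)cc32)cn1`) stands at 2.3, the higher of the two measured numbers, and compound 1 (`Cc1ccc(Cn2c(=O)[nH]c3c(N)nc(-c4ncco4)cc32)cn1`) gives 1.6. Compound 3 (`Cc1ccc(Cn2c(=O)[nH]c3c(N)nc(-n4cccn4)cc32)cn1`) carries 1H-pyrazol-1-yl in place of trifluoromethyl on an aromatic carbon, next to the ring nitrogen: 1H-pyrazol-1-yl in place of trifluoromethyl on an aromatic carbon. Among the compounds with values here, the one measured step that bears on this is a number 0.70 log units higher from compound 1 to compound 2 (beyond the scatter), modest and beyond the scatter, with trifluoromethyl in place of 1,3-oxazol-2-yl, also a five-membered aromatic ring. Taken in reverse, a number 0.70 log units higher from compound 1 to compound 2 (beyond the scatter) points to a lower number in this assay on leaving trifluoromethyl. No measurement compares the two rings, so the size of the change remains uncertain. A somewhat smaller step in that direction is expected, estimated as a number 0.40 log units lower from compound 2 to compound 3 (beyond the scatter). For compound 3 the estimate is 1.9, with an expected range from 1.5 to 2.3.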

Compound 3, distribution coefficient: 2.5
The estimate for compound 3 lay 0.60 log units below the measured number, outside the stated range (above it).
By their numbers in this assay, from the lowest: compound 1; then compounds 2 and 3 (each within the scatter of the next).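

In this assay, the exchange of trifluoromethyl for 1H-pyrazol-1-yl gives a number 0.20 log units higher from compound 2 to compound 3 (within the scatter), so these two groups cannot be told apart at this position, although only the entering group carries a ring and hydrogen-bond acceptors. The two five-membered aromatic rings do not read alike: a number 0.90 log units higher from compound 1 to compound 3 (beyond the scatter), so having a ring at this position does not by itself set the number, and 1,3-oxazol-2-yl alone stands apart among the three groups shown. Nothing measured on these compounds accounts for the difference between the two rings.

Still open, from the compounds shown here alone, is where an amine or a carboxylic acid at this position would fall in this assay. Also open, going by these compounds, is whether another five-membered ring, such as 1H-imidazol-1-yl, would group with compound 1 or with compound 3.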